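Removing a Methyl From Two Related Cores

The compounds below may be only part of what the source reports. "The series", "measured", "known", "first", "only" and "open" are said of these compounds alone.

Compound 1 `CSc1nc2c(C)nsc2[nH]1` and compound 2 `CSc1nc2cnsc2[nH]1` share a core and differ by one change, (hydrogen in place of methyl on an aromatic carbon). In a functional assay on HFF cells (Homo sapiens) for inhibition (a lower number here means a stronger inhibitor, a higher number a weaker inhibitor), compound 1 gives 26000 nM. In this assay compound 2 gives 32000 nM. The measured step between them, a 1.2-fold higher number from compound 1 to compound 2 (0.09 log units; within the scatter), lies within the usual scatter, so the two compounds count as equally strong inhibitors on this evidence.

Compound 3 `CSc1nc2c(C)nsc2n1[C@H]1C[C@H](O)[C@@H](CO)O1` carries a different core from compound 1, and the difference between the two cores is not broken down here. In this assay compound 3 gives only a limit, > 100000 nM, which is a boundary of the assay and not a number. (the limit of > 100000 nM in this assay, at which 1 of the 3 values shown sits).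

Compound 4 `CSc1nc2cnsc2n1[C@H]1C[C@H](O)[C@@H](CO)O1` stands to compound 3 as compound 2 stands to compound 1: the change is the same one, (hydrogen in place of methyl on an aromatic carbon), at the same place in the ring. Because the measured step of a 1.2-fold higher number from compound 1 to compound 2 (0.09 log units; within the scatter) stayed within the scatter, the step from compound 3 to compound 4 in this assay is expected to be small as well, a step that the limit leaves unreadable from compound 3 to compound 4. Compound 3 already sits at the limit, so compound 4 is expected to remain near or beyond that limit. Compound 4 is expected to give about 150000 nM in this assay, with a likely range from 60000 nM to 400000 nM.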

Compound 4, half-maximal inhibitory concentration: > 100000 nM
Compound 4 was reported as a limit; the forecaster's own chance of this, stated with the estimate: 75%; the middle value does not contradict the limit.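

In this assay, going by these compounds alone, compound 4 is reported only as a limit, > 100000 nM, and that is also the form of the result for compound 3, so no step between compound 3 and compound 4 can be read: the limit of > 100000 nM in this assay, at which 2 of the 4 values shown sit. The compounds shown leave open how strongly compound 3 and compound 4 really inhibit, and whether hydrogen in place of methyl makes any difference on this core.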